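Methylamino to ethylamino on compound 2

The compounds below may be only part of what the source reports. "The series", "measured", "known", "first", "only" and "open" are said of these compounds alone.

Going by the values given here, in a functional assay on GOTO cells (Homo sapiens) for cytotoxicity, read by MTT assay, with a stated time of 3 days (a lower number here means a stronger inhibitor, a higher number a weaker inhibitor), compound 1 `N#Cc1c(O)nc(SCc2nc3ccccc3[nH]2)nc1-c1ccccc1` gives 7.81 nM and compound 2 `CNc1nc(SCc2nc3ccccc3[nH]2)nc(-c2ccccc2)c1C#N` gives 3.28 nM, the lower of the two numbers so far. Compound 3 `CCNc1nc(SCc2nc3ccccc3[nH]2)nc(-c2ccccc2)c1C#N` is the next member to be read in this assay. Its difference from compound 2 is methyl in place of hydrogen on a saturated chain carbon bound to a nitrogen on an aromatic ring, which turns methylamino into ethylamino.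

Among the compounds with values here, only one measured step bears on this change: a 2.4-fold lower number from compound 1 to compound 2 (0.38 log units; beyond the scatter), a modest step beyond the scatter, with methylamino in place of hydroxy on an aromatic carbon. That step involves the same substituent but replaces one group with another of a different kind. Within the data shown here, no measured pair yet compares methylamino with a longer chain, so the data favour no direction. A small change, none beyond the scatter, is therefore expected in this assay. The estimated step is a 1.1-fold higher number from compound 2 to compound 3 (0.03 log units; within the scatter). For compound 3 the estimated value is 3.5 nM, with an expected range of 1.5 nM to 8 nM.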

Compound 3, half-maximal inhibitory concentration: 3.96 nM
Beside the measured number, compound 3's estimate is 1.1-fold (0.05 log units) below it; the measured number falls inside the stated range.
By their numbers in this assay, from the lowest: compounds 2, 3 and 1 (each within the scatter of the next, the first and the last beyond it).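

In this assay, going by these compounds alone, the one comparison of chain length on this amino nitrogen gives a 1.2-fold higher number from compound 2 to compound 3 (0.08 log units; within the scatter), so methyl in place of hydrogen on this saturated chain carbon, which turns methylamino into ethylamino, cannot be told from no change. Against the hydroxy compound, a 2.0-fold lower number from compound 1 to compound 3 (0.29 log units; within the scatter) lies within the scatter, whereas a 2.4-fold lower number from compound 1 to compound 2 (0.38 log units; beyond the scatter) lies beyond it, so the separation from hydroxy seen with methylamino is not clearly repeated with ethylamino, even though the two amino compounds themselves cannot be separated. No available evidence bears on the reason for any of these steps.

Still open, going by these compounds, is whether a longer chain such as propylamino, a branched group such as isopropylamino, or a cyclic amine such as morpholine would give a step beyond the scatter from compound 2. Also open, on these data alone, is whether the plain amino group would read with compound 2 and compound 3 or with compound 1, which would help show how much the chain on this nitrogen contributes.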